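Anilide aryl swap on the piperidine N-oxide series

The compounds below may be only part of what the source reports. "The series", "measured", "known", "first", "only" and "open" are said of these compounds alone.

Three compounds have numbers in a functional assay on HEK293 cells for agonist activity at D(4) dopamine receptor (Homo sapiens), read by FLIPR; a higher number here means that more compound is needed for the effect, a lower number that less compound is needed. Compound 1 `O=C(CN1CCC(c2cccc[n+]2[O-])CC1)Nc1cccc(Cl)c1` gives 62 nM, the lowest of the three. Compound 2 `C=Cc1cccc(C(=O)NCN2CCC(c3cccc[n+]3[O-])CC2)c1` gives 68 nM, within the scatter of compound 1. Compound 3 `O=C(NCN1CCC(c2cccc[n+]2[O-])CC1)c1cnccc1Cl` gives 1290 nM, far from both. Going by the values given here, the only single-point step among the measured compounds is a 19-fold higher number from compound 2 to compound 3 (1.28 log units; beyond the scatter); it sits on the carbonyl side of the amide, in a series where the amide is joined to the shared core through a different linker than in compound 1.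

Compound 4 `Cc1cc(F)ccc1NC(=O)CN1CCC(c2cccc[n+]2[O-])CC1` is not yet measured. It differs from compound 1 as follows: 4-fluoro-2-methylphenyl in place of 3-chlorophenyl on an amide-type nitrogen. Among the compounds with values here, no measured step touches the aryl on the amide-type nitrogen, so the step from compound 2 to compound 3 bears on it only indirectly, as a sign that the aryl groups of this series can move the number a great deal. With a halogen kept on the ring and a methyl added, the expectation is a small shift, a 1.6-fold higher number from compound 1 to compound 4 (0.21 log units; within the scatter), not clearly beyond the scatter. Compound 4 is expected to give 100 nM, with a range from 35 nM to 300 nM.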

Compound 4, half-maximal effective concentration: 60 nM
Compound 4: the middle estimate sits 1.7-fold (0.22 log units) above what was measured, within the range that was stated.
By their numbers in this assay, from the lowest: compounds 4, 1 and 2 (each within the scatter of the next); then compound 3.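

In this assay the aryl on the amide-type nitrogen now has a step of its own: 4-fluoro-2-methylphenyl in place of 3-chlorophenyl gives a 1.0-fold lower number from compound 1 to compound 4 (0.01 log units; within the scatter) and so leaves the number unchanged within the scatter. Here fluorine takes the place of chlorine and a methyl enters, yet nothing on the scale of the carbonyl-side swap appears, which gave a 19-fold higher number from compound 2 to compound 3 (1.28 log units; beyond the scatter) on a different linker. Nothing available explains why this swap leaves the number unchanged.

From the compounds shown here alone, it remains open whether the fluorine and the methyl would each leave the number unchanged alone, as 4-fluorophenyl and 2-methylphenyl would show, or whether their contributions offset each other. Also open, going by these compounds, is how the number responds on this nitrogen to a 4-chloropyridin-3-yl or to an aryl carrying an amine or a carboxylic acid.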